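A Biphenyl Sulfonyl Group Replaces the Diaminophenyl

The source may hold more compounds than are shown below. What is called first, only, known or untested is meant among the compounds shown, and "the series" means these compounds.

Of the compounds shown here, two have been measured in a functional assay on PC-3 cells (Homo sapiens) for inhibition; a lower number here means a stronger inhibitor, a higher number a weaker inhibitor. Compound 1 `COc1cc2nc(N3CCN(S(=O)(=O)c4ccc(Cl)s4)CC3)nc(N)c2cc1OC` gives 25000 nM, while compound 2 `COc1cc2nc(N3CCN(S(=O)(=O)c4ccc(N)cc4N)CC3)nc(N)c2cc1OC` gives 67000 nM. Within the data shown here, compound 2 therefore stands at the highest of the two numbers, with compound 1 its nearest neighbour, and the one measured step, a 2.7-fold higher number from compound 1 to compound 2 (0.43 log units; beyond the scatter), came from an exchange of the aryl group on the sulfonyl sulfur.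

Compound 3 `COc1cc2nc(N3CCN(S(=O)(=O)c4ccc(-c5ccccc5)cc4)CC3)nc(N)c2cc1OC` differs from compound 2 by 4-phenylphenyl in place of 2,4-diaminophenyl on a sulfonyl sulfur. Among the measured compounds shown here, the only measured step that bears on this change is the modest aryl exchange a 2.7-fold higher number from compound 1 to compound 2 (0.43 log units; beyond the scatter); no measured compound carries a 4-phenylphenyl group, so the direction is not settled by the data. Since compound 1, whose aryl group is also without the two amino groups, sits at the lower number 25000 nM, a step toward a lower number is expected, though a change within the scatter is also plausible. Compound 3 is accordingly expected to give 30000 nM, within a range from 8000 nM to 120000 nM. For compound 3 the expected step is a 2.2-fold lower number from compound 2 to compound 3 (0.35 log units; beyond the scatter).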

Compound 3, half-maximal inhibitory concentration: 4200 nM
Estimate against measurement, compound 3: 7.1-fold (0.85 log units) above; the whole stated range lies above it.
By their numbers in this assay, from the lowest: compound 3; then compound 1; then compound 2.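

In this assay, the group on the sulfonyl sulfur proves to matter far more than the first pair suggested, with a 16-fold lower number from compound 2 to compound 3 (1.20 log units; beyond the scatter) set against the earlier, modest a 2.7-fold higher number from compound 1 to compound 2 (0.43 log units; beyond the scatter). The 4-phenylphenyl group, with two six-membered aromatic rings of carbon only and no hydrogen-bond donors or acceptors, also improves on the 5-chlorothiophen-2-yl group, giving a 6.0-fold lower number from compound 1 to compound 3 (0.77 log units; beyond the scatter), which makes compound 3 the strongest inhibitor of the three and shows that this position accepts the largest of these aryl groups with a gain. Nothing available gives a reason for this gain.

The exchange from compound 2 to compound 3 removes the two amino groups and adds a second aromatic ring in one step, so the three compounds cannot say how much of the change belongs to each. A plain phenyl group on the sulfonyl sulfur would separate the two, while a naphthyl group or a benzyl group would begin to show whether the gain depends on the shape of the 4-phenylphenyl group or simply on a larger carbon-only aryl group.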